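A few compounds are considered here, and "the series" means these few. Any claim that something is new, unique, unknown or untested is made for them only; others in the source may bear on it.

Going by the values given here, compound 3 `CC(C)C(/C=C1/CCNC1=O)c1ccc(-c2ccc3cccc(F)c3c2)[nH]c1=O` gives 0.987 h in an ADME assay on microsomes from liver (Homo sapiens) for metabolic stability (a lower number here means that the compound disappears faster, a higher number that the compound lasts longer), the highest of the three numbers so far. Compound 2 `CC(C)C(/C=C1\CCNC1=O)c1ccc(-c2ccc3cccc(F)c3c2)[nH]c1=O` gives 0.713 h; between these two the step is a 1.4-fold higher number from compound 2 to compound 3 (0.14 log units; within the scatter), and what separates them is only (the fact that one of compounds 2 and 3 is drawn with a defined configuration and the other without, at the place where they differ). Compound 1 `CC(C)C(Nc1nccs1)c1ccc(-c2ccc3cccc(F)c3c2)[nH]c1=O` gives 0.17 h, and the steps away from it are a 4.2-fold higher number from compound 1 to compound 2 (0.62 log units; beyond the scatter) and a 5.8-fold higher number from compound 1 to compound 3 (0.76 log units; beyond the scatter).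

Compound 4 `CC(C)C(c1ncco1)c1ccc(-c2ccc3cccc(F)c3c2)[nH]c1=O` has not been measured. Relative to compound 3 the change is a group of 5 heavy atoms (3 carbon, 1 nitrogen, 1 oxygen; one five-membered aromatic ring with 2 hetero atoms) in place of a group of 7 heavy atoms (5 carbon, 1 nitrogen, 1 oxygen; one five-membered non-aromatic ring with 1 hetero atom), on a saturated chain carbon bound to an aromatic carbon and a saturated chain carbon. This runs in the opposite sense to the two steps that led away from compound 1, where a five-membered aromatic ring with 2 hetero atoms was replaced by the non-aromatic ring; the 1,3-oxazol-2-yl group entering compound 4 is again a five-membered aromatic ring with 2 hetero atoms, though not the same ring as in compound 1. Given a 5.8-fold higher number from compound 1 to compound 3 (0.76 log units; beyond the scatter) in reverse, the expectation for compound 4 is a lower number in this assay, of similar size, as a 3.9-fold lower number from compound 3 to compound 4 (0.60 log units; beyond the scatter). Compound 4 is therefore estimated at 0.25 h, with a range from 0.1 h to 0.6 h.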

Compound 4, half-life: 0.178 h
Compound 4: middle estimate off by 1.4-fold (0.15 log units), on the high side, and the stated range covers the measured number.
By their numbers in this assay, from the lowest: compounds 1 and 4 (each within the scatter of the next); then compounds 2 and 3 (each within the scatter of the next).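

In this assay, a second five-membered aromatic ring with 2 hetero atoms at this place, the 1,3-oxazol-2-yl group, gives a drop from both double-bond forms of the non-aromatic ring group: a 5.5-fold lower number from compound 3 to compound 4 (0.74 log units; beyond the scatter) and a 4.0-fold lower number from compound 2 to compound 4 (0.60 log units; beyond the scatter). Against the (1,3-thiazol-2-yl)amino group the result is a 1.0-fold higher number from compound 1 to compound 4 (0.02 log units; within the scatter), so these two aromatic groups cannot be told apart here, despite the amino link and the different ring. Among these four compounds, compounds 1 and 4 with aromatic rings sit together at the low end and compounds 2 and 3 with the non-aromatic ring at the high end, and none goes against this.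

A phenyl group or an open-chain amide at this place would test whether the split follows aromaticity of the ring or some other feature of the groups. Nothing at hand explains the gap between the two pairs.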